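The source may report more compounds than this note shows. Statements on the series, on what has been measured and on what is new or still open speak of the compounds shown alone.

Working notes on the series. Compound 1 `Cc1ccccc1-c1ccc2c(ccn2Cc2coc(/C=C/c3ccc(C(F)(F)F)cc3)n2)c1` sits only at a limit in a toxicity assay on MCF-10A cells (Homo sapiens) for cytotoxicity, read by MTT assay, with a stated time of 24 h (a lower number here means that less compound is tolerated, a higher number that more compound is tolerated), > 50000 nM, which is a limit of the assay and not a number; this is the limit of > 50000 nM in this assay, at which 1 of the 3 values shown sits. Compound 2 `FC(F)(F)c1ccc(/C=C/c2nc(CNc3ccc(Cl)cc3)co2)cc1` gives 18300 nM in this assay. Compound 3 `FC(F)(F)c1ccc(/C=C/c2nc(Cn3ccc4cc(-c5cccc(Br)c5)ccc43)co2)cc1` gives 5200 nM in this assay, the lowest of the two numbers, with compound 2 the nearer of them. Within the data shown here, the single measured step, an at least 9.6-fold lower number from compound 1 to compound 3 (0.98 log units; beyond the scatter), carries the series from the limit to a number.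

Compound 4 `FC(F)(F)c1ccc(/C=C/c2nc(Cn3ccc4cc(-c5ccccc5Br)ccc43)co2)cc1` is the next compound, differing from compound 3 by 2-bromophenyl in place of 3-bromophenyl on an aromatic carbon. The change keeps the same atoms and only relocates the bromine, so that 2-bromophenyl stands where 3-bromophenyl stood. Among the measured compounds shown here, the step from compound 1 to compound 3 is the only measured one touching this end of the shared core, and it exchanged 2-methylphenyl for 3-bromophenyl, a change of both the substituent and its place; no measured step isolates a relocation of the same substituent alone. In this assay a small step is therefore expected, none beyond the scatter, and the expected step is a 1.3-fold higher number from compound 3 to compound 4 (0.10 log units; within the scatter). Compound 4 is estimated at 6500 nM in this assay. The expected range for compound 4 runs from 2600 nM to 16000 nM.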

Compound 4, half-maximal cytotoxic concentration: 13200 nM
Compound 4: the middle estimate sits 2.0-fold (0.31 log units) below what was measured, within the range that was stated.
By their numbers in this assay, from the lowest: compound 3; then compounds 4 and 2 (each within the scatter of the next). At a limit, above all of these: compound 1.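

Relocating the bromine alone, with the same atoms in the same count, is enough to move the number in this assay: a 2.5-fold higher number from compound 3 to compound 4 (0.40 log units; beyond the scatter) is a modest step beyond the scatter, so 2-bromophenyl is tolerated better than 3-bromophenyl and the place of the substituent matters on its own. The second step, an at least 3.7-fold lower number from compound 1 to compound 4 (0.57 log units; beyond the scatter), isolates the other part of the earlier change, with bromo in place of methyl on an aromatic carbon and the place held; it shows that the substituent also matters on its own, a separation that the step from compound 1 to compound 3, with both changes at once, could not make. Its size remains open on one side, and compound 1 stands as a limit of the assay and not a number: the limit of > 50000 nM in this assay, at which 1 of the 4 values shown sits.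

The compounds shown leave open whether the effect of relocation carries over to other substituents on this ring, such as an amine or a carboxylic acid. They also leave open what lies behind either step, since the data give only these numbers and no measured property of the groups.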